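Oxygen-to-sulfoxide swap on the six-carbon chain

This account rests on a few compounds, and the source may have more. Where it says the series, first, only, none or still open, it means among the compounds named here.

Measured so far:
compound 1, `CCCCn1nc(-c2ccccc2)c(-c2ccccc2)cc1=O` — 176000 nM
compound 2, `CCCCCCOc1cc(-c2ccccc2)c(-c2ccccc2)nn1` — 72000 nM

In an assay on microsomes from liver for inhibition of sterol O-acyltransferase 1 (Rattus norvegicus) (on this read-out higher numbers stand for weaker inhibition and lower numbers for stronger inhibition), compound 1 gives 176000 nM. In the same assay compound 2 gives 72000 nM, the lowest of the two numbers recorded; compound 1 stands beyond the scatter above it. For the measured compounds named here, the two compounds differ in more than one place, so no single-change step is available, and only the two values themselves can be compared.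

Compound 3, `CCCCCC[S+]([O-])c1cc(-c2ccccc2)c(-c2ccccc2)nn1`, is the next entry. It differs from compound 2 in one place: a group of 8 heavy atoms (6 carbon, 1 oxygen, 1 sulfur; no ring) in place of a group of 7 heavy atoms (6 carbon, 1 oxygen; no ring), on an aromatic carbon. Going by the values given here, nothing measured so far shows how this assay responds to such a change, so no direction can be taken from earlier steps. The expectation is a step of modest size, possibly within the scatter. Compound 3 is therefore estimated at 60000 nM, with a plausible range from 15000 nM to 250000 nM. This estimate corresponds to a step of a 1.2-fold lower number from compound 2 to compound 3 (0.08 log units; within the scatter).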

Compound 3, half-maximal inhibitory concentration: 75000 nM
Compound 3: middle estimate off by 1.3-fold (0.10 log units), on the low side, within the range that was stated.
By their numbers in this assay, from the lowest: compounds 2 and 3 (each within the scatter of the next); then compound 1.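

In this assay, putting the six-carbon sulfoxide in place of hexyloxy on this aromatic carbon gives a 1.0-fold higher number from compound 2 to compound 3 (0.02 log units; within the scatter), so the two compounds cannot be told apart. For the compounds shown here, this is the first single-place comparison, and it shows that at this position, on this core and with this chain, the assay does not separate the oxygen-linked group from the sulfoxide-linked one. No measured evidence on the compounds bears on this result.

One step at one position does not show how the assay would respond to other groups there, such as an amine, a carboxylic acid, a sulfone or a longer chain. On these data alone, whether any group at this position would bring the number out of the range of compound 2 and compound 3 also remains open.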